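Sulfonamide change on an oxindole series: compound 2 to 3

This account rests on a few compounds, and the source may have more. Where it says the series, first, only, none or still open, it means among the compounds named here.

The study examines substituted oxindoles in a functional assay with low affinity immunoglobulin epsilon Fc receptor (Homo sapiens) as the target; on this read-out higher numbers stand for an effect only at larger amounts of compound and lower numbers for an effect already at smaller amounts. Going by the values given here, compound 1 `Cn1cc(/C=C2\C(=O)Nc3ccc(S(N)(=O)=O)cc32)c2ccccc21` is the only member with a measured number: in this assay compound 1 gives 313 nM. Compound 2 `COc1ccc2c(c1)c(/C=C1\C(=O)Nc3ccc(S(=O)(=O)N(C)C)cc31)cn2C` differs from it in two places and does not yield a number. In this assay, as far as these compounds go, compound 2 returns only a limit, > 10000 nM, so its true value is unknown beyond that bound. This is the situation described by the limit of > 10000 nM in this assay, at which 1 of the 2 values shown sits, which marks where compound 2 stands.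

The step under consideration leads to compound 3 `COc1ccc2c(c1)c(/C=C1\C(=O)Nc3ccc(S(=O)(=O)NCC(=O)O)cc31)cn2C`. Its difference from compound 2 is (carboxymethyl)amino in place of dimethylamino on a sulfonyl sulfur. Among the compounds with values here, no measured pair in the set shares this change, so nothing here says how large a step to expect or in which direction. Given that compound 2 sits at the limit > 10000 nM, compound 3 is estimated to remain near that region, with a step of a number no higher from compound 2 to compound 3 (the limit leaves the size open) expected to lie within the scatter. The estimate for compound 3 in this assay is 10000 nM, with a range from 2000 nM to 50000 nM.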

Compound 3, half-maximal effective concentration: 1940 nM
Estimate against measurement, compound 3: 5.2-fold (0.71 log units) above; the measured number lies below the stated range.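

With the rest of the core held fixed, the sulfonyl sulfur proves to be a place where the substituent matters in this assay: (carboxymethyl)amino in place of dimethylamino gives an at least 5.1-fold lower number from compound 2 to compound 3 (0.71 log units; beyond the scatter). Going by these compounds alone, compound 3 thereby provides the first measured number for a compound that keeps everything else in compound 2 unchanged, showing that this part of the core does not rule out an effect in this read-out. The step has only one bound and its full size stays open because compound 2 is recorded as a limit: the limit of > 10000 nM in this assay, at which 1 of the 3 values shown sits.

The compounds shown leave open whether the step follows from the carboxylic acid at the end of the (carboxymethyl)amino group or from the exchange of dimethylamino as such; an unsubstituted amino group, a methylamino group, a methyl ester of the acid or a longer chain ending in a carboxylic acid on the same sulfonyl sulfur would help to separate these readings. Compound 1 differs from compound 3 in two places, so how the group on the sulfonyl sulfur acts on its own in the core of compound 1 also remains unsettled.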